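The compounds below may be only part of what the source reports. "The series", "measured", "known", "first", "only" and "open" are said of these compounds alone.

Measured compounds:
Compound 1 `COc1c(OCCCCN2CCN(C)CC2)cc(O)c2c(=O)cc(-c3ccc(C(F)(F)F)cc3)oc12` gives 2400 nM in a functional assay on HepG2 cells (Homo sapiens) for cytotoxicity, read by MTT assay, with a stated time of 72 h; a higher number here means a weaker inhibitor, a lower number a stronger inhibitor.
Compound 2 `O=c1cc(-c2ccccc2)oc2c(OCCCN3CCCC3)c(OCc3ccccc3)cc(O)c12` gives 2660 nM in this assay.

Only these two numbers are known, and they lie within the scatter of each other, so compound 2 and compound 1 cannot be told apart on potency; compound 2 simply shares the picture of weak, low-micromolar cytotoxicity that both show.

Compound 3 `O=c1cc(-c2ccccc2)oc2c(OCCCCN3CCCC3)c(OCc3ccccc3)cc(O)c12` is not yet measured. It differs from compound 2 in one place: (pyrrolidin-1-yl)methyl in place of pyrrolidin-1-yl on a saturated chain carbon, three bonds along the chain from an oxygen on an aromatic ring. In plain terms, the chain that carries the basic ring is lengthened by one carbon, and nothing else on the shared core changes.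

Within the data shown here, no measured pair in this set reports the effect of such a chain lengthening, so there is no step to lean on. A single added carbon in a flexible chain is, on experience with changes of this size, usually a small shift, and the expected step of a 1.1-fold lower number from compound 2 to compound 3 (0.03 log units; within the scatter) is taken to be none beyond the scatter, in no settled direction. Compound 3 is therefore estimated at 2500 nM, with a range from 1200 nM to 5500 nM.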

Compound 3, half-maximal inhibitory concentration: 4660 nM
Beside the measured number, compound 3's estimate is 1.9-fold (0.27 log units) below it, within the range that was stated.
By their numbers in this assay, from the lowest: compounds 1, 2 and 3 (each within the scatter of the next).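

In this assay, among these compounds, moving from 3-(pyrrolidin-1-yl)propyl to 4-(pyrrolidin-1-yl)butyl gives the first direct reading of chain length at this position, and the result is a 1.8-fold higher number from compound 2 to compound 3 (0.24 log units; within the scatter). This single added carbon, placed three bonds along the chain from an oxygen on an aromatic ring, therefore leaves the two compounds indistinguishable, since repeated measurements of one compound could differ by as much. The data offer no independent measurement that could explain this result, whether for the cells or for the compounds themselves.

Among the compounds shown here, with only two chain lengths compared directly, no trend with length can be drawn, so it remains open whether a shorter 2-(pyrrolidin-1-yl)ethyl chain or a longer 5-(pyrrolidin-1-yl)pentyl chain would move the number beyond the scatter. It is also unknown whether the same one-carbon change would read alike with a different amine at the chain end, such as piperidine or morpholine, in place of the pyrrolidine ring.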